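The source may hold more compounds than are shown below. What is called first, only, known or untested is meant among the compounds shown, and "the series" means these compounds.

Measured so far in a toxicity assay on HMEC-1 cells (Homo sapiens) for cytotoxicity; a lower number here means a stronger inhibitor, a higher number a weaker inhibitor:

- compound 1 `COC1=C(Cc2ccc(Cl)cc2)C(=O)C2=C(NCCS2(=O)=O)C1=O` gives 8510 nM
- compound 2 `COC1=C(Cc2ccc(OC)cc2)C(=O)C2=C(NCCS2(=O)=O)C1=O` gives 17900 nM

Compound 2 has the higher number of the pair, which makes it the weaker inhibitor. Compound 3 `COC1=C(Cc2ccc(OC(F)(F)F)cc2)C(=O)C2=C(NCCS2(=O)=O)C1=O` carries trifluoromethyl in place of methyl on an oxygen on an aromatic ring, (trifluoromethyl in place of methyl on an oxygen on an aromatic ring). Among the measured compounds shown here, only one measured step bears on this change, a modest swap of chloro for methoxy on an aromatic carbon. Going by compound 2 and its step, a 2.1-fold higher number from compound 1 to compound 2 (0.32 log units; beyond the scatter), a similarly modest move toward a lower number is expected, although no trifluoromethoxy compound has been measured yet. The expected change is a 1.8-fold lower number from compound 2 to compound 3 (0.25 log units; within the scatter). For compound 3 the estimate is 10000 nM, with an expected range of 4500 nM to 22000 nM.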

Compound 3, half-maximal inhibitory concentration: 3590 nM
Beside the measured number, compound 3's estimate is 2.8-fold (0.44 log units) above it; the measured number lies below the stated range.
By their numbers in this assay, from the lowest: compound 3; then compound 1; then compound 2.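

In this assay the step of a 5.0-fold lower number from compound 2 to compound 3 (0.70 log units; beyond the scatter) shows that this position responds to a change on the oxygen alone, with the oxygen itself kept in place. The step of a 2.4-fold lower number from compound 1 to compound 3 (0.37 log units; beyond the scatter) takes trifluoromethoxy past chloro as well, leaving compound 3 with the lowest number of the three. No evidence is available to account for the size of either step.

Still open, from the compounds shown here alone, is how an amine or a carboxylic acid on the aromatic ring would compare, and whether a longer chain on the oxygen, such as ethoxy, would lower or raise the number.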